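A few compounds are considered here, and "the series" means these few. Any claim that something is new, unique, unknown or untested is made for them only; others in the source may bear on it.

Of the compounds shown here, three have been measured in an assay for inhibition of Amine oxidase [flavin-containing] B (Rattus norvegicus); on this read-out lower numbers stand for stronger inhibition and higher numbers for weaker inhibition. Compound 1 `N#CCCn1nc(-c2ccc(OCc3cccc(Cl)c3)cc2)oc1=S` gives 160 nM, and compound 2 `N#CCCn1nc(-c2ccc(OCc3ccc(Cl)cc3)cc2)oc1=S` gives 690 nM. The two share a core and differ in one place only: 4-chlorophenyl in place of 3-chlorophenyl on a saturated chain carbon bound to an oxygen on an aromatic ring. That change produced a 4.3-fold higher number from compound 1 to compound 2 (0.63 log units; beyond the scatter). Compound 3 `N#CCCN1N=C(c2ccc(OCc3cccc(Cl)c3)cc2)OCC1=O` is built on another core; how its core differs from the core of compound 1 is not broken down here. In this assay compound 3 gives 13 nM, the lowest of the three numbers. Compound 4 `N#CCCN1N=C(c2ccc(OCc3ccc(Cl)cc3)cc2)OCC1=O` has not yet been measured. It differs from compound 3 in the same way that compound 2 differs from compound 1, at the same place: 4-chlorophenyl in place of 3-chlorophenyl on a saturated chain carbon bound to an oxygen on an aromatic ring. The earlier step, a 4.3-fold higher number from compound 1 to compound 2 (0.63 log units; beyond the scatter), is the basis for expecting a step of similar direction and size this time, although it rests on a single pair and on a core that is not the core of compound 3. Compound 4 is therefore estimated at 55 nM, with an expected range from 20 nM to 160 nM. That estimate means an expected step of a 4.2-fold higher number from compound 3 to compound 4 (0.63 log units; beyond the scatter).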

Compound 4, half-maximal inhibitory concentration: 100 nM
Compound 4: middle estimate off by 1.8-fold (0.26 log units), on the low side, within the range that was stated.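

In this assay, putting 4-chlorophenyl in place of 3-chlorophenyl again gave weaker inhibition on the second core, with a 7.7-fold higher number from compound 3 to compound 4 (0.89 log units; beyond the scatter). The steps on the two cores point the same way and cannot be told apart in size, so in these two pairs the change carried over from one core to the other: the same change on two cores in this assay, a 4.3-fold higher number (0.63 log units; beyond the scatter) from compound 1 to compound 2 and a 7.7-fold higher number (0.89 log units; beyond the scatter) from compound 3 to compound 4, 1.8-fold (0.25 log units) apart, within the scatter of two such steps. Two pairs on two cores do not show that the same step would appear on a further core, and they do not explain why 3-chlorophenyl gives the lower number in both.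

All the compounds shown have chlorine on the benzyl ring, which leaves open whether a fluorine or a methoxy group in its place would show the same preference between these two ring positions. As far as these compounds go, they also share the same nitrile-bearing chain, so it remains open whether the step would hold with a longer chain or with an amine in place of the nitrile.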